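Ester in Place of Hydroxyethyl Ether on the Shared Core

The source may hold more compounds than are shown below. What is called first, only, known or untested is meant among the compounds shown, and "the series" means these compounds.

Compound 1 `CC[C@](C)(O)CC(=O)O[C@H](CC=C(C)C)C1=CC(=O)c2c(O)ccc(O)c2C1=O`: 30200 nM
Compound 2 `CC(C)=CC[C@@H](OCCO)C1=CC(=O)c2c(O)ccc(O)c2C1=O`: 18600 nM

In a functional assay on HeLa cells (Homo sapiens) for cytotoxicity, read by MTT assay (a lower number here means a stronger inhibitor, a higher number a weaker inhibitor), compound 2 holds the lowest of the two numbers, its nearest neighbour being compound 1, with a 1.6-fold lower number from compound 1 to compound 2 (0.21 log units; within the scatter). Compound 3 `CC(C)=CC[C@@H](OC(=O)c1ccoc1)C1=CC(=O)c2c(O)ccc(O)c2C1=O` differs from compound 2 only at one place: (furan-3-yl)carbonyl in place of 2-hydroxyethyl on an oxygen on a saturated carbon. Going by the values given here, the one measured step bears on it, since it also exchanged an ester for 2-hydroxyethyl on that oxygen and stayed within the scatter. Compound 3 is therefore expected to show a step of a 1.3-fold higher number from compound 2 to compound 3 (0.11 log units; within the scatter) with no change beyond the scatter. Compound 3 is estimated at 24000 nM, within 8000 nM to 70000 nM.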

Compound 3, half-maximal inhibitory concentration: > 100000 nM
Compound 3 gave a limit, no number (the forecaster's own chance of this, stated with the estimate: 10%); middle value at least 4.1-fold (0.61 log units) from the limit.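

In this assay, the group on this oxygen matters more than the earlier pair suggested: (furan-3-yl)carbonyl in place of 2-hydroxyethyl gave an at least 5.3-fold higher number from compound 2 to compound 3 (0.73 log units; beyond the scatter). The ester link alone does not account for this, since furan-3-yl in place of 2-hydroxy-2-methylbutyl on the carbonyl carbon gave an at least 3.3-fold higher number from compound 1 to compound 3 (0.51 log units; beyond the scatter). Compound 3 gave only a limit, not a number: the limit of > 100000 nM in this assay, at which 1 of the 3 values shown sits.

From the compounds shown here alone, the full size of both steps therefore stays open. So does whether a benzoyl group or a 2-aminoethyl group on the same oxygen would read like compound 3 or like compound 2.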